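The source may hold more compounds than are shown below. What is called first, only, known or untested is meant among the compounds shown, and "the series" means these compounds.

Measured in a functional assay on CCRF-CEM cells (Homo sapiens) for cytotoxicity; a higher number here means a weaker inhibitor, a lower number a stronger inhibitor:
compound 1 `CC(C)n1cnc2c(NCc3cccc(O)c3)nc(NCCCO)nc21`: 17600 nM
compound 2 `CC(C)C(CO)Nc1nc(NCc2ccccc2O)c2ncn(C(C)C)c2n1`: 4400 nM

Compound 2 holds the lower of the two numbers, and its gap to compound 1 lies beyond the scatter. Compound 3 `CC(C)C(CO)Nc1nc(NCc2cccc(O)c2)c2ncn(C(C)C)c2n1`, not yet measured, carries 3-hydroxyphenyl in place of the 2-hydroxyphenyl of compound 2 on a saturated chain carbon bound to a nitrogen on an aromatic ring (3-hydroxyphenyl in place of 2-hydroxyphenyl on a saturated chain carbon bound to a nitrogen on an aromatic ring). Within the data shown here, no step between measured compounds speaks to this change. No shift beyond the scatter is expected in this assay, in either direction. The expected move is a 1.1-fold higher number from compound 2 to compound 3 (0.06 log units; within the scatter) on this estimate. For compound 3 the estimated value is 5000 nM, with an expected range from 1800 nM to 14000 nM for a single measurement.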

Compound 3, half-maximal inhibitory concentration: 6700 nM
For compound 3 the middle estimate is 1.3-fold (0.13 log units) below the measured one, within the range that was stated.
By their numbers in this assay, from the lowest: compounds 2 and 3 (each within the scatter of the next); then compound 1.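

In this assay, 3-hydroxyphenyl in place of 2-hydroxyphenyl on a saturated chain carbon bound to a nitrogen on an aromatic ring makes no clear difference (a 1.5-fold higher number from compound 2 to compound 3 (0.18 log units; within the scatter)), so neither hydroxyphenyl stands apart at this position. Compound 3 also allows a one-place reading of the other nitrogen substituent: 1-(hydroxymethyl)-2-methylpropyl in place of 3-hydroxypropyl gives a modest gain beyond the scatter (a 2.6-fold lower number from compound 1 to compound 3 (0.42 log units; beyond the scatter)). No measurement at hand explains either step.

From the compounds shown here alone, whether unsubstituted phenyl or 4-hydroxyphenyl at the same place would shift the number remains open. So does whether an aminoalkyl chain in place of 1-(hydroxymethyl)-2-methylpropyl would keep that gain.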